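Morpholin-4-yl for azepan-1-yl on the sulfonyl sulfur

A few compounds are considered here, and "the series" means these few. Any claim that something is new, unique, unknown or untested is made for them only; others in the source may bear on it.

In an ADME assay on Vero cells (Chlorocebus sabaeus) for cytotoxicity, read by MTT assay (a lower number here means that less compound is tolerated, a higher number that more compound is tolerated), compound 3 (`Cn1nc(C(F)(F)F)cc1C(=O)Nc1ccc(S(=O)(=O)N2CCCCCC2)cc1`) gives no number, only a limit (> 300000 nM). Of the other compounds, compound 1 (`CCn1nc(C(F)(F)F)cc1C(=O)Nc1ccc(S(=O)(=O)N2CCCCC2C)cc1`) gives a number (30000 nM). For compound 2 (`COC(=O)c1ccccc1-n1nc(C(F)(F)F)cc1C(=O)Nc1ccc(S(=O)(=O)N2CCCC2)cc1`) no result exists ("not determined" (no result reported)). For the measured compounds named here, no two measured compounds differ in one place, so no measured step bears on the change at hand.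

Compound 4 (`Cn1nc(C(F)(F)F)cc1C(=O)Nc1ccc(S(=O)(=O)N2CCOCC2)cc1`) carries morpholin-4-yl in place of azepan-1-yl on a sulfonyl sulfur. The expectation rests on compound 3, which stands at the limit of > 300000 nM in this assay, at which 1 of the 3 values shown sits, and so leaves the true size of any step open. The estimated step of an at least 1.2-fold lower number from compound 3 to compound 4 (0.07 log units; that floor lies within the scatter) is expected to stay within the usual scatter, with no firm direction in this assay and a fair chance that only a limit is reported again. The estimate for compound 4 is 250000 nM with an expected range (70000 nM to 600000 nM).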

Compound 4, half-maximal cytotoxic concentration: > 300000 nM
Compound 4: no number, only a limit; the forecaster's own chance of this, stated with the estimate: 55%; middle value at least 1.2-fold (0.07 log units) away from the limit.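

In this assay, compound 3 and compound 4 each give only a limit, so no step can be read between them: the limit of > 300000 nM in this assay, at which 2 of the 4 values shown sit.

As far as these compounds go, whether morpholin-4-yl in place of azepan-1-yl on a sulfonyl sulfur shifts the half-maximal cytotoxic concentration at all, and by how much, stays open.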